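Replacing the difluorophenyl ring on the carbonyl side

The source may report more compounds than this note shows. Statements on the series, on what has been measured and on what is new or still open speak of the compounds shown alone.

Compound 1 `CN(C(=O)NC(=O)c1c(F)cccc1F)c1nc(C(F)(F)F)c(C(=O)N/N=C/c2cccc(C(F)(F)F)c2)s1`: 21.8 ug/mL in a functional assay on MCF7 cells (Homo sapiens) for inhibition, read by MTT assay, with a stated time of 72 h; a higher number here means a weaker inhibitor, a lower number a stronger inhibitor
Compound 2 `CN(C(=O)NC(=O)c1c(F)cccc1F)c1nc(C(F)(F)F)c(C(=O)N/N=C/c2ccccc2C(F)(F)F)s1`: 20.4 ug/mL

Compound 1 and compound 2 lie within the scatter of each other: a 1.1-fold lower number from compound 1 to compound 2 (0.03 log units; within the scatter). Compound 3 `CN(C(=O)NC(=O)c1cccc(C(F)(F)F)c1)c1nc(C(F)(F)F)c(C(=O)N/N=C/c2cccc(C(F)(F)F)c2)s1` differs from compound 1 by 3-(trifluoromethyl)phenyl in place of 2,6-difluorophenyl on a carbonyl carbon. For the measured compounds named here, the one measured step alters a different ring, on the carbon double-bonded to nitrogen, and stays within the scatter, so nothing measured here speaks to the ring on the carbonyl carbon. Compound 3 is therefore expected to stay close to compound 1, a 1.0-fold higher number from compound 1 to compound 3 (0.00 log units; within the scatter), with an estimated 22 ug/mL and a range of 8 ug/mL to 60 ug/mL.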

Compound 3, half-maximal inhibitory concentration: 3.7 ug/mL
The estimate for compound 3 lay 5.9-fold (0.77 log units) above the measured number; the whole stated range lies above it.
By their numbers in this assay, from the lowest: compound 3; then compounds 2 and 1 (each within the scatter of the next).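

The ring on the carbonyl carbon clearly affects the result in this assay (a 5.9-fold lower number from compound 1 to compound 3 (0.77 log units; beyond the scatter)). For the compounds shown here, the earlier step, on a carbon with a double bond to nitrogen, stayed within the scatter, so this is the first change to move the number beyond it. No measurement here offers an explanation for the step.

One swap cannot separate losing the two fluorines from gaining the trifluoromethyl group. Going by these compounds, it also remains open how a plain phenyl ring, or a ring carrying a methoxy group or a carboxylic acid, would behave on this carbonyl carbon.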